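Bromo to 2-Hydroxyphenyl: Expected Cytotoxicity of Compound 3

A few compounds are considered here, and "the series" means these few. Any claim that something is new, unique, unknown or untested is made for them only; others in the source may bear on it.

In an ADME assay on HEL cells (Homo sapiens) for cytotoxicity, with a stated time of 3 days (on this read-out lower numbers stand for higher toxicity in this test and higher numbers for lower toxicity in this test), compound 1 (`Cc1cc(-c2ccc(O)cc2)cn2c(CSCCc3ccccc3)cnc12`) gives > 50 ug/mL, a limit of the assay.
In this assay compound 2 (`Cc1cc(Br)cn2c(CSCCc3ccccc3)cnc12`) gives 28 ug/mL.

For the measured compounds named here, compound 2 thus holds the only number reported in this assay; the other result sits at the limit of > 50 ug/mL in this assay, at which 1 of the 2 values shown sits. Compound 3 (`Cc1cc(-c2ccccc2O)cn2c(CSCCc3ccccc3)cnc12`) differs from compound 2 by 2-hydroxyphenyl in place of bromo on an aromatic carbon. Going by the values given here, one measured step bears on this change, running the opposite way: an at least 1.7-fold lower number from compound 1 to compound 2 (0.25 log units; that floor lies within the scatter). Since a hydroxyphenyl re-enters where bromo leaves, the number is expected to rise, with the result possibly again a limit, which is the estimated step of a 1.8-fold higher number from compound 2 to compound 3 (0.25 log units; within the scatter). Compound 3 is therefore estimated at 50 ug/mL, within 20 ug/mL to 120 ug/mL.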

Compound 3, half-maximal cytotoxic concentration: > 50 ug/mL
Compound 3: no number, only a limit; the forecaster's own chance of this, stated with the estimate: 50%; the middle value lies on the limit itself.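

With 2-hydroxyphenyl on this aromatic carbon, this assay shows an at least 1.7-fold higher number from compound 2 to compound 3 (0.25 log units; that floor lies within the scatter). For the compounds shown here, a second hydroxyphenyl compound thus joins compound 1 at the limit, leaving the bromo compound 2 as the only one with a number: the limit of > 50 ug/mL in this assay, at which 2 of the 3 values shown sit. The step between the 2-hydroxyphenyl and 4-hydroxyphenyl compounds cannot be read, so these two groups cannot be told apart here. Still open, on these data alone, is whether a plain phenyl, an aminophenyl or a carboxylic acid on this carbon would also reach the limit.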